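Compound 2 to compound 4: working notes

This account rests on a few compounds, and the source may have more. Where it says the series, first, only, none or still open, it means among the compounds named here.

compound 1 `C=C[C@]1(C)C[C@@H](OC(=O)CNC(=O)Nc2ccc(OC)cc2)[C@]2(C)[C@H](C)CC[C@]3(CCC(=O)[C@H]32)[C@@H](C)[C@@H]1O`: > 10000 nM
compound 2 `C=C[C@]1(C)C[C@@H](OC(=O)CNC(=O)NC(=O)c2cccc(F)c2)[C@]2(C)[C@H](C)CC[C@]3(CCC(=O)[C@H]32)[C@@H](C)[C@@H]1O`: > 10000 nM
compound 3 `C=C[C@]1(C)C[C@@H](OC(=O)CNC(=O)Nc2ccc(F)cc2F)[C@]2(C)[C@H](C)CC[C@]3(CCC(=O)[C@H]32)[C@@H](C)[C@@H]1O`: > 10000 nM

All three readings come from a functional assay on U-87MG ATCC cells for inhibition, with U-87 MG (Homo sapiens) as the target, read by MTT assay, with a stated time of 72 h (on this read-out higher numbers stand for weaker inhibition and lower numbers for stronger inhibition), and none is a number. Compound 2 stands at > 10000 nM as a limit of the assay and nothing finer. The whole measured set shares one position, namely the limit of > 10000 nM in this assay, at which 3 of the 3 values shown sit, and no ranking can be drawn from it.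

The next compound is compound 4 `C=C[C@]1(C)C[C@@H](OC(=O)CNC(=O)Nc2ccccc2Br)[C@]2(C)[C@H](C)CC[C@]3(CCC(=O)[C@H]32)[C@@H](C)[C@@H]1O` and the change is 2-bromophenyl in place of (3-fluorophenyl)carbonyl on an amide-type nitrogen with 2-bromophenyl in place of (3-fluorophenyl)carbonyl on an amide-type nitrogen.

Among the measured compounds shown here, three measured steps bear on this nitrogen: a step that the two limits leave unreadable from compound 1 to compound 2 and a step that the two limits leave unreadable from compound 1 to compound 3 and a step that the two limits leave unreadable from compound 2 to compound 3 and none of them has a readable size. They give no direction and no sign of a change beyond the usual scatter. The expected outcome is a step that the limit leaves unreadable from compound 2 to compound 4 with no direction favoured.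

For compound 4 the estimate is 14000 nM within an expected range of 5000 nM to 40000 nM and another limit is the likeliest report.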

Compound 4, half-maximal inhibitory concentration: > 10000 nM
Compound 4 was reported as a limit; the forecaster's own chance of this, stated with the estimate: 80%; the middle value does not contradict the limit.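

Among the compounds shown here, compound 4 gives > 10000 nM, which is a limit of the assay, so no step between it and compound 1, compound 2 or compound 3 can be read. The compounds shown leave open whether any group on the amide-type nitrogen gives a measurable value in this assay, as all share one position: the limit of > 10000 nM in this assay, at which 4 of the 4 values shown sit.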